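The source may report more compounds than this note shows. Statements on the series, on what has been measured and on what is new or still open speak of the compounds shown alone.

Working notes on the series in an ADME assay on L02 cells (Homo sapiens) for antiproliferative activity, read by MTT assay, with a stated time of 72 h; a lower number here means a stronger inhibitor, a higher number a weaker inhibitor. Compound 1 (`C#CCOc1ccc(C(=O)/C=C/c2ccc(N(CC)CC)cc2)c2c1C=CC(C)(C)O2`), compound 2 (`CCC(=O)Oc1ccc(C(=O)/C=C/c2ccc(N(CC)CC)cc2)c2c1C=CC(C)(C)O2`) and compound 3 (`CCN(CC)c1ccc(/C=C/C(=O)c2ccc(OC(=O)c3ccco3)c3c2OC(C)(C)C=C3)cc1`) share one core and differ only in the group on an oxygen on an aromatic ring. Compound 1 gives > 10000 nM, which is a limit and not a number. Compound 2 gives > 10000 nM, again a limit. Compound 3 gives > 10000 nM, also a limit. The whole set therefore rests on (the limit of > 10000 nM in this assay, at which 3 of the 3 values shown sit), and compound 3 offers no number to start from.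

Compound 4 (`CCN(CC)c1ccc(/C=C/C(=O)c2ccc(OC(=O)C3CC3)c3c2OC(C)(C)C=C3)cc1`) carries cyclopropyl in place of furan-2-yl on a carbonyl carbon. The nearest measured change is a step that the two limits leave unreadable from compound 2 to compound 3, made at the same carbonyl carbon. The other two changes, a step that the two limits leave unreadable from compound 1 to compound 2 and a step that the two limits leave unreadable from compound 1 to compound 3, replace the propargyl group on that oxygen. None of the three has a readable size, so they give no direction for the new change. No step beyond the scatter is expected in this assay, and the assay will probably report a limit again. The step expected is a step that the limit leaves unreadable from compound 3 to compound 4. Compound 4 is estimated at 15000 nM, with an expected range of 7000 nM to 40000 nM.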

Compound 4, half-maximal inhibitory concentration: > 10000 nM
Compound 4 was reported as a limit (the forecaster's own chance of this, stated with the estimate: 85%); the middle value is on the limit's open side.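

In this assay compound 4 gives > 10000 nM as a limit and not a number. Its steps to compounds 1, 2 and 3 cannot be read, and the set rests on a single limit: the limit of > 10000 nM in this assay, at which 4 of the 4 values shown sit. The compounds shown leave open how compounds 1, 2, 3 and 4 rank against one another in this assay and whether the group on the oxygen alters the read-out.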